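The source may report more compounds than this note shows. Statements on the series, on what has been measured and on what is new or still open speak of the compounds shown alone.

Compound 1 `COc1cc(C(c2ccc(O)c(OC)c2)[C@@H](C)[C@H](C)CF)ccc1O` gives 37000 nM in a functional assay on HeLa cells (Homo sapiens) for cytotoxicity, read by WST assay, with a stated time of 48 h; a higher number here means a weaker inhibitor, a lower number a stronger inhibitor. Among the two numbers in hand it stands lowest, with compound 2 `COc1ccc(C(c2ccc(OC)c(OC)c2)[C@H](C)[C@@H](C)CO)cc1OC` nearest at 67000 nM, a gap that lies within the scatter. Compound 3 `COc1ccc(C(c2ccc(OC)c(OC)c2)[C@H](C)[C@H](C)CO)cc1OC` returns only > 100000 nM, which is a limit of the assay and not a number. For the measured compounds named here, the single measured step, an at least 1.4-fold higher number from compound 2 to compound 3 (0.17 log units; that floor lies within the scatter), is a change of configuration alone. Compound 4 `COc1cc(C(c2ccc(O)c(OC)c2)[C@@H](CF)C(C)C)ccc1O` differs from compound 1 by 1-(fluoromethyl)-2-methylpropyl in place of 2-(fluoromethyl)-1-methylpropyl on a saturated chain carbon bound to two aromatic carbons. Going by the values given here, no measured step concerns a rearrangement of this kind, so the data give no direction. The expected step is therefore a 1.1-fold higher number from compound 1 to compound 4 (0.03 log units; within the scatter), nothing beyond the scatter. Compound 4 is estimated at 40000 nM in this assay, with a range from 15000 nM to 100000 nM.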

Compound 4, half-maximal inhibitory concentration: 41000 nM
Compound 4: middle estimate off by 1.0-fold (0.01 log units), on the low side; the measured number falls inside the stated range.
By their numbers in this assay, from the lowest: compounds 1, 4 and 2 (each within the scatter of the next). At a limit, above all of these: compound 3.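

Replacing 2-(fluoromethyl)-1-methylpropyl with 1-(fluoromethyl)-2-methylpropyl on a saturated chain carbon bound to two aromatic carbons gives a 1.1-fold higher number from compound 1 to compound 4 (0.04 log units; within the scatter) in this assay. For the compounds shown here, this is the first measured step in which the chain itself is rearranged, and the number at this position stays within the scatter, even with 1 defined stereocentre in the entering group against 2 in the group that leaves. No measurement in hand bears on the reason for this result.

From the compounds shown here alone, how this position responds to an amine, a carboxylic acid or a longer chain remains open.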